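Acyl Swap on the Ring Nitrogen of Compound 3

The source may hold more compounds than are shown below. What is called first, only, known or untested is meant among the compounds shown, and "the series" means these compounds.

Within the data shown here, compound 3 `COc1ccc2ccc(=O)oc2c1C1=NN(C(N)=O)C(c2ccc(C)cc2)C1` stands second highest of the three numbers so far in a functional assay on HepG2 cells (Homo sapiens) for cytotoxicity, read by MTT assay, with a stated time of 72 h (a higher number here means a weaker inhibitor, a lower number a stronger inhibitor), where compound 3 gives 46 nM. Its nearest neighbour is compound 1 `COc1ccc2ccc(=O)oc2c1C1=NNC(c2ccc(C)cc2)C1`, which in this assay gives 43 nM; the furthest is compound 2 `COc1ccc2ccc(=O)oc2c1C1=NN(C(C)=O)C(c2ccc(C(F)(F)F)cc2)C1`, which in this assay gives 80 nM. Both gaps lie within the scatter.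

Compound 4 `COc1ccc2ccc(=O)oc2c1C1=NN(C(C)=O)C(c2ccc(C)cc2)C1` carries the change (methyl in place of amino on a carbonyl carbon).

Among the measured compounds shown here, one measured step bears on the same amine nitrogen in the ring: a 1.1-fold higher number from compound 1 to compound 3 (0.03 log units; within the scatter). That step, carbamoyl in place of hydrogen, lay within the scatter. For the measured compounds named here, compound 2 already carries an acetyl on that nitrogen, but paired with trifluoromethyl in place of methyl elsewhere in the molecule, so no single-change step is available; its value and that of compound 3 lie within the scatter of each other. Methyl in place of amino on the carbonyl carbon is therefore expected to shift this assay by no more than the scatter, with no direction favoured. The expected step is a 1.2-fold higher number from compound 3 to compound 4 (0.08 log units; within the scatter). Compound 4 is estimated at 55 nM, with a range from 25 nM to 120 nM.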

Compound 4, half-maximal inhibitory concentration: 50 nM
For compound 4 the middle estimate is 1.1-fold (0.04 log units) above the measured one, and the stated range covers the measured number.
By their numbers in this assay, from the lowest: compounds 1, 3, 4 and 2 (each within the scatter of the next).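

In this assay, carbamoyl to acetyl on the carbonyl carbon attached to the amide-type nitrogen in the ring gives a 1.1-fold higher number from compound 3 to compound 4 (0.04 log units; within the scatter), so this position keeps its number within the scatter when the amino group and its hydrogen-bond donor leave. Acetyl in place of hydrogen on that nitrogen now has a single-change reading of its own, a 1.2-fold higher number from compound 1 to compound 4 (0.07 log units; within the scatter), which agrees with the carbamoyl step, a 1.1-fold higher number from compound 1 to compound 3 (0.03 log units; within the scatter), in staying within the scatter, so neither acyl group separates from the unsubstituted nitrogen of compound 1. Among these compounds, compound 4 also gives the first single-change reading for methyl in place of trifluoromethyl on an aromatic carbon, a 1.6-fold lower number from compound 2 to compound 4 (0.20 log units; within the scatter), and this too stays within the scatter, although no measurement on hand accounts for any of these steps.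

The compounds shown leave open whether a longer acyl chain, a benzoyl group or a carboxylic acid on the ring nitrogen would move the number beyond the scatter. They also leave open whether chlorine or methoxy on that aromatic carbon would do so.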